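This account rests on a few compounds, and the source may have more. Where it says the series, first, only, none or still open, it means among the compounds named here.

Compounds measured so far:
compound 1 `C[C@H](c1ccc(F)cc1)N(Cc1cccc(C(=O)O)c1)C(=O)c1cccc(-c2ccccc2)c1` – 837 nM
compound 2 `C[C@H](c1ccc(F)cc1)N(Cc1cccc(C(=O)O)c1)C(=O)c1cc2ccccc2s1` – 145 nM
compound 3 `CC(c1ccc(F)cc1)N(Cc1cccc(C(=O)O)c1)C(=O)c1ccc2c(c1)CCO2` – 3620 nM

In an assay on CHO T-rex cells for antagonist activity at transient receptor potential cation channel subfamily M member 8 (Homo sapiens), read by calcium flux, with a stated time of 20 min (on this read-out higher numbers stand for weaker inhibition and lower numbers for stronger inhibition), compound 2 gives the lowest number of the three; compound 1 stands nearest, with a higher number that lies beyond the scatter, and compound 3 stands furthest, with a still higher number, also beyond the scatter. Compound 4 `C[C@H](c1ccc(F)cc1)N(Cc1cccc(C(=O)O)c1)C(=O)c1cn2ccccc2n1` differs from compound 2 in one place: a group of 9 heavy atoms (7 carbon, 2 nitrogen; one five-membered aromatic ring with 2 hetero atoms, one six-membered aromatic ring with 1 hetero atom) in place of a group of 9 heavy atoms (8 carbon, 1 sulfur; one five-membered aromatic ring with 1 hetero atom, one six-membered aromatic ring of carbon only), on a carbonyl carbon. Within the data shown here, no measured pair shows this kind of exchange, so nothing seen here tells how large the step should be. Compound 4 is expected to give a weaker inhibition than compound 2, with a step of a 4.1-fold higher number from compound 2 to compound 4 (0.62 log units; beyond the scatter) that goes beyond the scatter. For compound 4 the estimate in this assay is 600 nM, within a range from 150 nM to 2500 nM.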

Compound 4, half-maximal inhibitory concentration: 307 nM
For compound 4 the middle estimate is 2.0-fold (0.29 log units) above the measured one; the measured number falls inside the stated range.
By their numbers in this assay, from the lowest: compound 2; then compound 4; then compound 1; then compound 3.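

In this assay the step of a 2.1-fold higher number from compound 2 to compound 4 (0.33 log units; beyond the scatter) is modest but beyond the scatter. On this carbonyl carbon, then, 1-benzothiophen-2-yl can give way to a group of the same heavy-atom count, with nitrogen in place of sulfur and 2 hydrogen-bond acceptors instead of 1, at a limited loss of inhibition. No measurement at hand accounts for this step. As far as these compounds go, it remains open whether a single thiophene or pyridine ring on that carbonyl carbon would stay close to these two compounds. An indole group there is equally unresolved.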